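From 4-fluorophenyl to 3-chlorophenyl in a macrophage toxicity test

A few compounds are considered here, and "the series" means these few. Any claim that something is new, unique, unknown or untested is made for them only; others in the source may bear on it.

compound 1 `O=C(Nc1cc(-c2ccccn2)n[nH]1)N1CCN(c2ccc(F)cc2)CC1`: > 57000 nM
compound 2 `O=C(Nc1cc(-c2ccccn2)n[nH]1)N1CCC(c2ccc(F)cc2)CC1`: > 64000 nM
compound 3 `O=C(NCc1ccccc1)Nc1[nH]nc(-c2ccccn2)c1C1CC1`: > 45000 nM

All three entries come from an ADME assay on cells (Peritoneal macrophage cell, Mus musculus) for cytotoxicity, read by fluorescence and resazurin assay, with a stated time of 3 days (on this read-out higher numbers stand for lower toxicity in this test and lower numbers for higher toxicity in this test), and each is a limit of the assay rather than a number. Compound 2 stands at > 64000 nM, which is a limit. The other two compounds also give only limits, so no order among the three can be read.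

Compound 4 `O=C(Nc1cc(-c2ccccn2)n[nH]1)N1CCC(c2cccc(Cl)c2)CC1` has not yet been measured. It differs from compound 2 by 3-chlorophenyl in place of 4-fluorophenyl on a saturated ring carbon. Among the compounds with values here, no step between measured compounds is available to size this change, so no shift beyond the usual scatter is expected in this assay, and another limit is the likeliest report. The estimated step is an at least 1.2-fold lower number from compound 2 to compound 4 (0.10 log units; that floor lies within the scatter), which is expected to stay small. For compound 4 the estimated value is 50000 nM, with an expected range from 20000 nM to 80000 nM.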

Compound 4, half-maximal cytotoxic concentration: > 22000 nM
Compound 4 gave a limit, no number (the forecaster's own chance of this, stated with the estimate: 70%); the middle value is on the limit's open side.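

In this assay, compound 2 and compound 4 both give limits rather than numbers, and the step between them cannot be read. The compounds shown leave open whether 3-chlorophenyl in place of 4-fluorophenyl on a saturated ring carbon changes this read-out at all.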